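This account rests on a few compounds, and the source may have more. Where it says the series, first, only, none or still open, it means among the compounds named here.

Working notes on the series. Compound 1 `C/C=C/C=C/C(=O)N(Cc1ccc(OC)c(O)c1)c1cc(OC)c(OC)c(OC)c1` is the reference: in a functional assay on KYSE-450 cells (Homo sapiens) for inhibition, read by MTT assay, with a stated time of 48 h (a higher number here means a weaker inhibitor, a lower number a stronger inhibitor), compound 1 gives 180 nM, the lowest of the two numbers in hand. Compound 2 `COc1ccc(N(Cc2cc(OC)c(OC)c(OC)c2)C(=O)CCl)cc1O` gives 29800 nM, a far higher number, beyond the scatter.

Compound 3 `COc1ccc(CN(C(=O)C[Se]C#N)c2cc(OC)c(OC)c(OC)c2)cc1O` differs from compound 1 by a group of 4 heavy atoms (2 carbon, 1 nitrogen, 1 selenium; no ring) in place of a group of 5 heavy atoms (5 carbon; no ring), on a carbonyl carbon. Among the measured compounds shown here, no pair of measured compounds separated by one change is available, so the size of this step can only be guessed. Compound 3 is expected to be weaker, the step from compound 1 estimated as a 17-fold higher number from compound 1 to compound 3 (1.22 log units; beyond the scatter). For compound 3 the estimate is 3000 nM, with a range of 500 nM to 20000 nM.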

Compound 3, half-maximal inhibitory concentration: 280 nM
For compound 3 the middle estimate is 11-fold (1.03 log units) above the measured one, outside the stated range (below it).
By their numbers in this assay, from the lowest: compounds 1 and 3 (each within the scatter of the next); then compound 2.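

On the carbonyl carbon, the penta-1,3-dien-1-yl group and the selenocyanatomethyl group read alike in this assay, with a 1.6-fold higher number from compound 1 to compound 3 (0.19 log units; within the scatter). Among the compounds shown here, this is the first one-place step, and it shows that this position accepts two quite different ringless groups, one with two double bonds and one with a triple bond, with no change beyond the scatter. Nothing measured on these compounds accounts for this.

The compounds shown leave open whether the selenium atom matters, since the sulfur counterpart, thiocyanatomethyl, is not among them. A saturated chain such as pentyl at this carbonyl carbon also remains an open comparison.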